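The source may hold more compounds than are shown below. What is called first, only, known or untested is meant among the compounds shown, and "the series" means these compounds.

Measured compounds and their values:
- Compound 1, `COc1ccc(-c2nc(-c3ccccc3)c(-c3ccc4c(c3)NC(=O)CO4)[nH]2)cc1`: 96%
- Compound 2, `O=C1COc2ccc(-c3nn(-c4cc(Cl)cc(Cl)c4)cc3-c3ccccc3)cc2N1`: 90.3%
- Compound 3, `O=C1COc2ccc(-c3nn(-c4ccccc4)cc3-c3ccccc3)cc2N1`: 77%

In a functional assay on DLD-1 cells (Homo sapiens) for cytotoxicity, read by colorimetric assay and MTT assay, with a stated time of 3 days, tested at 1 uM (a higher number here means a weaker effect of the compound at the concentration tested, a lower number a stronger effect), compound 1 gives the highest of the three numbers. Its value and that of compound 2 lie within the scatter of each other, so no order between them can be drawn; compound 3 lies beyond the scatter below compound 1. Among the measured compounds shown here, the one step among the measured compounds, a number 13.3 percentage points lower from compound 2 to compound 3 (beyond the scatter), concerns a change at an aromatic nitrogen of a different core and only loosely bears on the change now considered.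

Compound 4, `O=C1COc2ccc(-c3[nH]c(-c4ccc(F)cc4)nc3-c3ccccc3)cc2N1`, differs from compound 1 in one place: fluoro in place of methoxy on an aromatic carbon. For the measured compounds named here, no measured step reports this exchange on this core. Given that a swap of one small group on an aryl ring elsewhere in the set moved this assay only modestly, a step of similar or smaller size is expected here, with no clear direction. Compound 4 is therefore estimated at 91%, within 76% to 100%, which means an expected step of a number 5 percentage points lower from compound 1 to compound 4 (within the scatter), within the scatter.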

Compound 4, a percentage reported as activity, at one concentration (the size of the read-out at that concentration, not a potency): 94.8%
Beside the measured number, compound 4's estimate is 3.8 percentage points below it; low and high end bracket the measured number.
By their numbers in this assay, from the lowest: compound 3; then compounds 2, 4 and 1 (each within the scatter of the next).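

In this assay, among the compounds shown here, the exchange of 4-methoxyphenyl for 4-fluorophenyl comes with a number 1.2 percentage points lower from compound 1 to compound 4 (within the scatter), the first reading of any change at this position on the core of compound 1. The read-out therefore does not separate the two groups at the tested concentration, although methoxy is counted with a hydrogen-bond acceptor and fluoro with none. Nothing measured here offers an explanation for this result.

From the compounds shown here alone, with only these two groups at this position, it remains open whether an amine, a carboxylic acid or a longer alkoxy chain there would shift the read-out beyond the usual scatter. Going by these compounds, a single concentration also gives no potency, so any difference between compound 1 and compound 4 at other concentrations remains unknown.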